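The compounds below may be only part of what the source reports. "The series", "measured", "known", "first", "only" and "open" are said of these compounds alone.

Measured so far in a functional assay, with a stated time of 30 min; on this read-out higher numbers stand for weaker inhibition and lower numbers for stronger inhibition:

Compound 1, `CCCCCCCCCCCCOc1cc(OC)c(Br)cc1C(C)=O`, gives 29500000 nM.
Compound 2, `CCCCCCCCCCCCCCOc1cc(OC)c(Br)cc1C(C)=O`, gives 16100000 nM.
Compound 3, `CCCCCCCCCCCCCCOc1cc(OC)ccc1C(C)=O`, gives 43600000 nM.

All three numbers are very high on this read-out. The change ethyl in place of hydrogen on a saturated chain carbon, ten or more bonds along the chain from an oxygen on an aromatic ring gave a 1.8-fold lower number from compound 1 to compound 2 (0.26 log units; within the scatter). The change hydrogen in place of bromo on an aromatic carbon is not a counted difference here; the step itself is a 2.7-fold higher number from compound 2 to compound 3 (0.43 log units; beyond the scatter). The difference between the core of compound 1 and the core of compound 3 is not broken down here; compound 1 gives 29500000 nM and compound 3 gives 43600000 nM, and those two numbers stand close to each other.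

Compound 4, `CCCCCCCCCCCCCCCCOc1cc(OC)ccc1C(C)=O`, has not been measured. It differs from compound 3 by ethyl in place of hydrogen on a saturated chain carbon, ten or more bonds along the chain from an oxygen on an aromatic ring, the same change as that made from compound 1 to compound 2, since the two place descriptions agree word for word. On the strength of a 1.8-fold lower number from compound 1 to compound 2 (0.26 log units; within the scatter), the step is expected to be small: a 1.8-fold lower number from compound 3 to compound 4 (0.26 log units; within the scatter), taken as an estimate. Compound 4 is therefore expected to give about 24000000 nM, with the estimate most likely to fall between 12000000 nM and 50000000 nM.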

Compound 4, half-maximal inhibitory concentration: 39400000 nM
The estimate for compound 4 lay 1.6-fold (0.22 log units) below the measured number, and the stated range covers the measured number.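

In this assay, ethyl in place of hydrogen on a saturated chain carbon, ten or more bonds along the chain from an oxygen on an aromatic ring, gives a 1.1-fold lower number from compound 3 to compound 4 (0.04 log units; within the scatter). Set beside the earlier step, the change reads the same on both cores, with no difference between them beyond the scatter: the same change on two cores in this assay, a 1.8-fold lower number (0.26 log units; within the scatter) from compound 1 to compound 2 and a 1.1-fold lower number (0.04 log units; within the scatter) from compound 3 to compound 4, 1.7-fold (0.22 log units) apart, within the scatter of two such steps. Both steps lie within the scatter, so the pair shows that this change carries from the core of compound 1 to the core of compound 3 without a detectable shift, but it does not show that the change has any real effect on either core, or that this agreement would hold on a further core.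

The compounds shown leave open whether a shorter chain, or an amine or a carboxylic acid carried on the chain, would move these very high numbers by more than the scatter. They also leave open whether replacing bromo with chloro would shift the number, and whether the bromo step holds on a different chain.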